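Working notes: methoxy to hydroxy on the aromatic ring

The compounds below may be only part of what the source reports. "The series", "measured", "known", "first", "only" and "open" are said of these compounds alone.

Values in a functional assay on A549 cells (Homo sapiens) for cytotoxicity, read by MTT assay, with a stated time of 72 h (on this read-out lower numbers stand for stronger inhibition and higher numbers for weaker inhibition), for the measured compounds:
- Compound 1 `COc1ccc(/C=C2\CCC/C(=C\c3cccc(Br)c3)C2=O)cc1OC` gives 12800 nM
- Compound 2 `COc1cc(/C=C2\CCC/C(=C\c3ccc(OC)c(OC)c3)C2=O)ccc1O` gives 10300 nM

Among the measured compounds shown here, compound 2 at 10300 nM lies within the scatter of compound 1, the only other measured compound, so neither ranks ahead. Compound 3 `COc1ccc(/C=C2\CCC/C(=C\c3ccc(O)c(O)c3)C2=O)cc1OC` follows from compound 2 by hydrogen in place of methyl on an oxygen on an aromatic ring with hydrogen in place of methyl on an oxygen on an aromatic ring, turning 4-hydroxy-3-methoxyphenyl into 3,4-dihydroxyphenyl. For the measured compounds named here, the sole measured step is a 1.2-fold lower number from compound 1 to compound 2 (0.09 log units; within the scatter) and it concerns a different change, so it bears only indirectly and offers thin guidance. No step beyond the scatter is therefore expected in this assay and the estimated change is a 1.3-fold lower number from compound 2 to compound 3 (0.11 log units; within the scatter) at most a small one. For compound 3 the estimate is 8000 nM with an expected range of 3000 nM to 18000 nM in this assay.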

Compound 3, half-maximal inhibitory concentration: > 20000 nM
Compound 3 was reported as a limit; the forecaster's own chance of this, stated with the estimate: 5%; at least 2.5-fold (0.39 log units) between middle value and limit.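

In this assay compound 3 gives only a limit, > 20000 nM. Methoxy to hydroxy, turning 4-hydroxy-3-methoxyphenyl into 3,4-dihydroxyphenyl, gives an at least 1.9-fold higher number from compound 2 to compound 3 (0.28 log units; that floor lies within the scatter), and 3,4-dihydroxyphenyl in place of 3-bromophenyl gives an at least 1.5-fold higher number from compound 1 to compound 3 (0.19 log units; that floor lies within the scatter). This position therefore shows no gain from the added hydroxy, though neither floor clears the usual scatter.

The full size of both steps stays unread because compound 3 sits at a limit: the limit of > 20000 nM in this assay, at which 1 of the 3 values shown sits. Also open, from the compounds shown here alone, is how an amine or a carboxylic acid in place of that hydroxy would read.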